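The source may hold more compounds than are shown below. What is called first, only, known or untested is meant among the compounds shown, and "the series" means these compounds.

Compounds measured so far, with their read-outs:

- compound 1, `CNC(=O)[C@@]12C[C@@H]1[C@@H](n1cnc3cnc(C#Cc4ccc(Cl)s4)nc31)[C@H](O)[C@@H]2O`: < 10%
- compound 2, `CNC(=O)[C@@]12C[C@@H]1[C@@H](n1cnc3c(/C=C(\O)c4ccc(C(C)(C)C)cc4)nc(C#Cc4ccc(C(C)(C)C)cc4)nc31)[C@H](O)[C@@H]2O`: 24%
- compound 3, `CNC(=O)[C@@]12C[C@@H]1[C@@H](n1cnc3c(/C=C(\O)c4ccccc4)nc(Cl)nc31)[C@H](O)[C@@H]2O`: 30%

All three share the same core and were tested in an assay on CHO cells for displacement of a labelled ligand from adenosine receptor A1 (Homo sapiens), read by scintillation counting, with a stated time of 60 min, tested at 10 uM; a lower number here means less inhibition, a higher number more inhibition at the concentration tested (going by the name of the read-out). Compound 2 returns a number in this assay, 24%. Compound 3 likewise returns a number, 30%, and those two values sit within the usual scatter of each other. Compound 1 is different: its read-out of < 10% is a limit of this assay, not a number, so all that is known is that compound 1 gave less inhibition than the assay can resolve, as the limit of < 10% in this assay, at which 1 of the 3 values shown sits, records.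

Compound 4, `CNC(=O)[C@@]12C[C@@H]1[C@@H](n1cnc3cnc(C#Cc4ccc(F)c(F)c4)nc31)[C@H](O)[C@@H]2O`, is the next compound to be measured. It differs from compound 1 in one place: 3,4-difluorophenyl in place of 5-chlorothiophen-2-yl on a triple-bonded carbon. Both groups hang from the same triple-bonded carbon, so the rest of the structure is untouched.

For the measured compounds named here, with no measured step to lean on, the expectation for this assay is a small step, a number at least 2 percentage points higher from compound 1 to compound 4 (that floor lies within the scatter), from compound 1 to compound 4, one that may well stay within the scatter. Compound 4 is therefore expected to give about 12% in this assay, with a likely range from 2% to 30%.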

Compound 4, a percentage reported as inhibition, at one concentration (the size of the read-out at that concentration, not a potency): 17%
Beside the measured number, compound 4's estimate is 5 percentage points below it, within the range that was stated.
By their numbers in this assay, from the lowest: compounds 4, 2 and 3 (each within the scatter of the next, the first and the last beyond it). At a limit, below all of these: compound 1.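

For the compounds shown here, replacing 5-chlorothiophen-2-yl with 3,4-difluorophenyl on the triple-bonded carbon gives the first readable step at this position in this assay, a number at least 7 percentage points higher from compound 1 to compound 4 (that floor lies within the scatter). Compound 1 reads < 10%, which is a limit and not a number, so the step has only a floor and its true size remains unknown: the limit of < 10% in this assay, at which 1 of the 4 values shown sits.

With that floor inside the usual scatter, this pair shows that the group at the end of the triple bond can be exchanged and still give a measurable number, but it does not by itself establish a real gain in inhibition.

The exchange alters the ring size, the hetero atom and the halogens all at once, so this single pair cannot show which of these differences, if any, matters. Also open, going by these compounds, is how other groups on the same triple-bonded carbon would read at this one concentration, such as a pyridin-3-yl ring, a plain butyl chain or a chain ending in an amine, and whether any of them would move the read-out clearly beyond the scatter.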